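A (tert-butyl)carbonyl on the amine of compound 3

This account rests on a few compounds, and the source may have more. Where it says the series, first, only, none or still open, it means among the compounds named here.

Of the compounds shown here, three sharing one core have been measured in an ADME assay on BaF3 cells (Mus musculus) for cytotoxicity, read by CellTiter-Glo and CCK-8 assay, with a stated time of 72 h; a lower number here means a stronger inhibitor of growth, a higher number a weaker inhibitor of growth. Going by the values given here, compound 1 `CCC(=O)NCc1cccc(C(=O)Nc2ccc(C)c(Nc3nccc(-c4cccnc4)n3)c2)c1` gives 4750 nM, the only true number among them. Compound 2 `CCC(=O)Nc1cc(C(=O)Nc2ccc(C)c(Nc3nccc(-c4cccnc4)n3)c2)cc(C(F)(F)F)c1` reads > 10000 nM, which is a limit of the assay and not a number. Compound 3 `Cc1ccc(NC(=O)c2ccc(CNCCN(C)C)cc2)cc1Nc1nccc(-c2cccnc2)n1` reads > 10000 nM, which is likewise a limit. The position of compound 3 is therefore (the limit of > 10000 nM in this assay, at which 2 of the 3 values shown sit), and it offers no number of its own as a starting point.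

Compound 4 `Cc1ccc(NC(=O)c2ccc(CN(CCN(C)C)C(=O)C(C)(C)C)cc2)cc1Nc1nccc(-c2cccnc2)n1` differs from compound 3 in one place: (tert-butyl)carbonyl in place of hydrogen on an amine nitrogen. In words, (tert-butyl)carbonyl stands in place of hydrogen on an amine nitrogen. Among the compounds with values here, no measured pair shows this change, so the data give no direct size for it in this assay. A small step toward stronger growth inhibition is expected, or none beyond the scatter. This expectation rests on compound 3, with its limit of > 10000 nM, and the assay may well report a limit again. The expected step is small: an at least 1.1-fold lower number from compound 3 to compound 4 (0.04 log units; that floor lies within the scatter). For compound 4 the estimated value is 9000 nM, with an expected range from 3500 nM to 20000 nM.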

Compound 4, concentration for 50% growth inhibition: > 10000 nM
Compound 4 gave a limit, no number; the forecaster's own chance of this, stated with the estimate: 55%; at least 1.1-fold (0.04 log units) between middle value and limit.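

In this assay compound 4 gives > 10000 nM, which is a limit of the assay and not a number. Compound 3 also stands at a limit, so no step can be read between compound 3 and compound 4. The compounds shown leave open whether (tert-butyl)carbonyl in place of hydrogen on an amine nitrogen changes growth inhibition at all. Most of the set now rests at one value: the limit of > 10000 nM in this assay, at which 3 of the 4 values shown sit.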